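The source may hold more compounds than are shown below. What is called first, only, known or untested is meant among the compounds shown, and "the series" means these compounds.

Measured in a functional assay on HeLa cells (Homo sapiens) for inhibition, read by MTT assay, with a stated time of 48 h; a lower number here means a stronger inhibitor, a higher number a weaker inhibitor:
- compound 1 `CCOC(=O)C1=C(N/N=C(\C#N)C(N)=O)Nc2[nH]nc(C)c2C1c1ccc(N(C)C)cc1`: 47300 nM
- compound 2 `CCOC(=O)C1=C(N/C=N/c2ncc(-c3ccccc3)s2)Nc2[nH]nc(C)c2C1c1ccc(N(C)C)cc1`: 15400 nM
- compound 3 `CCOC(=O)C(=NNC1=C(C(=O)OCC)C(c2ccc(N(C)C)cc2)c2c(C)n[nH]c2N1)C(=O)OCC`: 83800 nM

Compound 1 sits close to compound 3, with a 1.8-fold higher number from compound 1 to compound 3 (0.25 log units; within the scatter). Compound 2, at 15400 nM, shows a clearly lower number than compound 1, at 47300 nM, and it also lies below compound 3. Going by the values given here, compound 2 therefore goes against any reading that changes on this nitrogen leave this assay unmoved, although no single-place step is available for it.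

Compound 4 `CCOC(=O)C1=C(N)Nc2[nH]nc(C)c2C1c1ccc(N(C)C)cc1` is the next case, and it differs from compound 1 by a hydrogen atom in place of a group of 7 heavy atoms (3 carbon, 3 nitrogen, 1 oxygen; no ring), on an amine nitrogen. The place is an amine nitrogen whose other neighbour is a double-bonded ring carbon. Among the compounds with values here, the one measured step that bears on this is a 1.8-fold higher number from compound 1 to compound 3 (0.25 log units; within the scatter), where one group without a ring on that nitrogen replaced another. Within the data shown here, that exchange was small, but no measured compound carries hydrogen at this place, so the comparison is only indirect. The expected step is therefore none beyond the scatter, though the uncertainty is wide, and it is estimated as a 1.1-fold higher number from compound 1 to compound 4 (0.02 log units; within the scatter). For compound 4 the estimated value is 50000 nM, with an expected range from 20000 nM to 125000 nM.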

Compound 4, half-maximal inhibitory concentration: 6220 nM
For compound 4 the middle estimate is 8.0-fold (0.91 log units) above the measured one, outside the stated range (below it).
By their numbers in this assay, from the lowest: compound 4; then compound 2; then compounds 1 and 3 (each within the scatter of the next).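

In this assay, the amine nitrogen whose other neighbour is a double-bonded ring carbon proves sensitive to the loss of its group, although exchanging one group without a ring for another had stayed within the scatter. Replacing the group of compound 1 with a hydrogen atom gives a 7.6-fold lower number from compound 1 to compound 4 (0.88 log units; beyond the scatter), and replacing the larger group of compound 3 gives a 13-fold lower number from compound 3 to compound 4 (1.13 log units; beyond the scatter), so among these three compounds the lower number goes with hydrogen on this nitrogen, and neither of the two groups matches it. The compounds shown offer no measurement that explains this shift.

A single methyl group, an acetyl group or a longer alkyl chain on this nitrogen appears in none of the compounds shown, so it remains open whether the lower number requires hydrogen itself or would persist with a group much smaller than those in compound 1 and compound 3. From the compounds shown here alone, it is also open whether the same replacement would give a step of similar size on the core of compound 1 with a different group in place of the dimethylamino-bearing aryl substituent.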